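The source may report more compounds than this note shows. Statements on the series, on what has been measured and on what is new or still open speak of the compounds shown alone.

In a functional assay on the whole organism (strain Sprague-Dawley) for inhibition, with Rattus norvegicus as the target, with a stated time of 10 min (on this read-out higher numbers stand for an effect only at larger amounts of compound and lower numbers for an effect already at smaller amounts), compound 1 (`CCCOc1ccccc1-c1ncc(C(=O)OCC)c(=O)[nH]1`) gives 5 mg/kg, the higher of the two exact numbers available. Compound 2 (`CCCCOc1ccccc1-c1ncc(C(=O)OCC)c(=O)[nH]1`) gives 0.5 mg/kg. Adding a methyl to the end of the chain gave a 10-fold lower number from compound 1 to compound 2 (1.00 log units; beyond the scatter). Compound 3 (`CCOC(=O)c1cnc(-c2ccccc2SCC)[nH]c1=O`) is reported only as a limit, > 5 mg/kg. Replacing propoxy with ethylsulfanyl gave a number no lower from compound 1 to compound 3 (the limit leaves the size open). Compound 4 (`CCCOc1ccc(OC)cc1-c1ncc(C(=O)OCC)c(=O)[nH]1`) keeps the propoxy group, with methoxy in place of hydrogen on an aromatic carbon. For the measured compounds named here, neither measured step changes that carbon, so they show only that a modest step is possible in this small set and indicate no direction. The estimated step is no change at the digits printed from compound 1 to compound 4 (within the scatter), with neither direction favoured. For compound 4 the expected value is 5 mg/kg, with an estimated range of 1 mg/kg to 20 mg/kg.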

Compound 4, dose for 50% inhibition: 0.7 mg/kg
For compound 4 the middle estimate is 7.1-fold (0.85 log units) above the measured one; the measured number lies below the stated range.
By their numbers in this assay, from the lowest: compounds 2 and 4 (each within the scatter of the next); then compound 1.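

The earlier steps shown here changed only the group on the oxygen or replaced that group, whereas this is a change at a different carbon of the aromatic ring. Methoxy para to the propoxy group gives a 7.1-fold lower number from compound 1 to compound 4 (0.85 log units; beyond the scatter) in this assay, so this carbon is a place where a substituent of 2 heavy atoms lets the compound act at a smaller dose. Nothing available explains why this change has that effect.

From the compounds shown here alone, how a hydroxyl, an amine or a longer alkoxy chain at this carbon would compare remains open. Also open, going by these compounds, is whether methoxy would give a similar step in a compound carrying butoxy instead of propoxy.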